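The compounds below may be only part of what the source reports. "The series", "measured", "known", "first", "only" and "open" are said of these compounds alone.

Measured so far:
- compound 1, `COc1ccc(F)cc1CNCCCNc1ccnc2cc(Cc3ccc(C#N)cc3)ccc12`: 6050 nM
- compound 2, `CC(C)Cc1ccc2c(NCCCNCc3ccco3)ccnc2c1`: 16000 nM
- compound 3, `FC(F)(F)c1cc(-c2ccc3c(NCCCNCc4ccco4)ccnc3c2)cc(C(F)(F)F)c1`: 2410 nM

These three compounds were tested in an ADME assay on HepG2 cells (Homo sapiens) for cytotoxicity, read by luminescence, CellTiter-Glo and ATP content, with a stated time of 72 h; on this read-out lower numbers stand for an effect already at smaller amounts and higher numbers for an effect only at larger amounts of compound. Compound 1 stands second highest of the three numbers. Its nearest neighbour is compound 3, whose number is lower by a step beyond the usual scatter; the furthest is compound 2, whose number is higher, again beyond the scatter. No two of the three compounds differ in only one place, so none of these gaps can be tied to a single structural change.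

Compound 4, `COc1ccc(-c2ccc3c(NCCCNCc4cc(F)ccc4OC)ccnc3c2)cc1`, has not yet been measured in this assay. It differs from compound 1 by 4-methoxyphenyl in place of 4-cyanobenzyl on an aromatic carbon. The rest of the molecule is kept.

Going by the values given here, since no step between two measured compounds matches this change, the expectation for compound 4 rests on the spread of the three values alone. The step from compound 1 to compound 4 is expected to be small, a 1.3-fold lower number from compound 1 to compound 4 (0.13 log units; within the scatter), pointing slightly downward but not beyond the scatter. Compound 4 is therefore expected to give about 4500 nM in this assay, with a likely range from 1500 nM to 13000 nM.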

Compound 4, half-maximal effective concentration: 5960 nM
Compound 4: middle estimate off by 1.3-fold (0.12 log units), on the low side, and the stated range covers the measured number.
By their numbers in this assay, from the lowest: compound 3; then compounds 4 and 1 (each within the scatter of the next); then compound 2.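

In this assay, putting 4-methoxyphenyl in place of 4-cyanobenzyl on this aromatic carbon gives a 1.0-fold lower number from compound 1 to compound 4 (0.01 log units; within the scatter) and so produces no change that can be told from the scatter. Going by these compounds alone, this is the first comparison here that isolates a single place, and it shows that this position accepts either of these two ring-bearing groups without a readable shift in cytotoxicity. The swap alters the group at the ring's far end and the way the ring is attached, yet no explanation can be offered for the flat result, as no supporting measurement is available.

From the compounds shown here alone, whether the nitrile and the methoxy group would matter separately remains open, and 4-cyanophenyl or 4-methoxybenzyl at this place would address that. A carboxylic acid or a primary amine here could also behave differently from both groups.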